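A few compounds are considered here, and "the series" means these few. Any claim that something is new, unique, unknown or untested is made for them only; others in the source may bear on it.

- Compound 1 `COc1ccccc1OC[C@@H]1CCc2cc([C@H]3CC[C@](N)(CO)C3)ccc2C1`: 14 h
- Compound 2 `N[C@]1(CO)CC[C@H](c2ccc3c(c2)CC[C@@H](COc2ccc(F)cc2)C3)C1`: 46 h
- Compound 3 `Cc1ccc(OC[C@@H]2CCc3cc([C@H]4CC[C@](N)(CO)C4)ccc3C2)cc1`: 35 h

In an ADME assay on the whole organism (Rattus norvegicus, strain Lewis) for metabolic stability, at a dose of 2 mg/kg by the oral route (on this read-out higher numbers stand for a longer-lived compound and lower numbers for a shorter-lived compound), compound 2 gives 46 h and stands in the upper group of the three numbers. The gap to its nearest neighbour is a 1.3-fold lower number from compound 2 to compound 3 (0.12 log units; within the scatter), and the widest gap is a 3.3-fold higher number from compound 1 to compound 2 (0.52 log units; beyond the scatter).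

Compound 4 `COc1cccc(SC[C@@H]2CCc3cc([C@H]4CC[C@](N)(CO)C4)ccc3C2)c1` carries (3-methoxyphenyl)sulfanyl in place of 4-fluorophenoxy on a saturated chain carbon bound to a saturated ring carbon. For the measured compounds named here, no measured step exchanges the oxygen for sulfur, so that part of the change has no direct support in the data. Going by the values given here, the closest guide is compound 1, the only measured compound with a methoxy group, which gives 14 h. The other relevant step, a 2.5-fold higher number from compound 1 to compound 3 (0.40 log units; beyond the scatter), is also modest. A modest fall in this assay is therefore expected, towards compound 1 but not fully reaching it. The expected step is a 2.1-fold lower number from compound 2 to compound 4 (0.32 log units; beyond the scatter). For compound 4 the estimated half-life is 22 h, with an expected range of 9 h to 50 h.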

Compound 4, half-life: 21 h
Compound 4: middle estimate off by 1.0-fold (0.02 log units), on the high side, within the range that was stated.
By their numbers in this assay, from the lowest: compounds 1, 4, 3 and 2 (each within the scatter of the next, the first and the last beyond it).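

In this assay, the (3-methoxyphenyl)sulfanyl group is the only sulfur-linked group shown at this place, on a saturated chain carbon bound to a saturated ring carbon, and replacing 4-fluorophenoxy with it gives a 2.2-fold lower number from compound 2 to compound 4 (0.34 log units; beyond the scatter). The same group cannot be told apart from the other two aryl ethers, with a 1.7-fold lower number from compound 3 to compound 4 (0.22 log units; within the scatter) and a 1.5-fold higher number from compound 1 to compound 4 (0.18 log units; within the scatter), even though those two ethers differ from each other, with a 2.5-fold higher number from compound 1 to compound 3 (0.40 log units; beyond the scatter). Nothing at hand accounts for these differences.

The exchange alters the linking atom and the ring substituent together, and the compounds shown do not separate the two. A 3-methoxyphenoxy or a (4-fluorophenyl)sulfanyl group at this place would divide the step into its two parts.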